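The source may hold more compounds than are shown below. What is called first, only, known or untested is meant among the compounds shown, and "the series" means these compounds.

Measured compounds and their values in an ADME assay on HepG2 2.2.15 cells (Homo sapiens) for cytotoxicity, read by MTT assay, with stated times of 48 h and 9 days; a lower number here means that less compound is tolerated, a higher number that more compound is tolerated:

- compound 1 `O=C(/C=C/c1coc2cc(O)ccc2c1=O)NCc1ccc(F)cc1`: 357000 nM
- compound 2 `COc1ccc2c(=O)c(/C=C/C(=O)Nc3ccccc3)coc2c1`: 523000 nM
- compound 3 `O=C(/C=C/c1coc2cc(O)ccc2c1=O)NCc1ccccc1`: 436000 nM

All three compounds share a core and differ only in the group attached to the amide. Compound 2 carries the highest of the three numbers, yet its gaps to compound 3 and to compound 1 both lie within the scatter, so the three values cannot be told apart.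

Compound 4 `COc1ccc(NC(=O)/C=C/c2coc3cc(OC)ccc3c2=O)cc1` has not yet been measured. It differs from compound 2 by methoxy in place of hydrogen on an aromatic carbon.

For the measured compounds named here, only one measured step touches the same phenyl ring: a 1.2-fold higher number from compound 1 to compound 3 (0.09 log units; within the scatter). Going by the values given here, that change, hydrogen in place of fluoro on an aromatic carbon, lies within the scatter, and no measured pair shows a methoxy entering this ring. The data therefore give no reason to expect a step beyond the scatter in this assay for compound 4, in either direction.

On that basis compound 4 is expected to give about 500000 nM in this assay, within a range of 250000 nM to 1000000 nM, which corresponds to an expected step of a 1.0-fold lower number from compound 2 to compound 4 (0.02 log units; within the scatter).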

Compound 4, half-maximal cytotoxic concentration: 718000 nM
Compound 4: middle estimate off by 1.4-fold (0.16 log units), on the low side; the range from low to high includes it.
By their numbers in this assay, from the lowest: compounds 1, 3, 2 and 4 (each within the scatter of the next).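

In this assay, adding a methoxy to the phenyl ring of compound 2 gives a 1.4-fold higher number from compound 2 to compound 4 (0.14 log units; within the scatter), so the change from phenyl to 4-methoxyphenyl, para to a large group, stays within the scatter. The earlier step, a 1.2-fold higher number from compound 1 to compound 3 (0.09 log units; within the scatter), only exchanged a fluoro for a hydrogen, whereas this change brings in a group of 2 heavy atoms with 1 hydrogen-bond acceptor, and the tolerated concentration still cannot be told apart from that of the parent compound. No measurement at hand bears on what lies behind this result.

Going by these compounds, whether an amine, a carboxylic acid or a longer chain at this same place would move the number beyond the scatter remains open. So does the effect of a methoxy at another position on this phenyl ring.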